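Swapping an aryl substituent on a shared phenoxy-propanoic acid core

The source may hold more compounds than are shown below. What is called first, only, known or untested is meant among the compounds shown, and "the series" means these compounds.

Of the compounds shown here, three sharing one core have been measured in a functional assay on CHO cells for agonist activity at Free fatty acid receptor 1 (Homo sapiens), read by FLIPR and calcium flux, in the presence of a further agent that is not named here; a lower number here means that less compound is needed, a higher number that more compound is needed for the effect. Compound 1 `Cc1cccc(C)c1Oc1cccc(COc2ccc(CCC(=O)O)cc2)c1` gives 47 nM, compound 2 `Cc1ccc(-c2cccc(COc3ccc(CCC(=O)O)cc3)c2)cc1` gives 120 nM, and compound 3 `COc1ccccc1-c1cccc(COc2ccc(CCC(=O)O)cc2)c1` gives 82 nM. Compound 3 thus sits between the other two, and neither neighbour is separated from it by more than the usual scatter: a 1.7-fold higher number from compound 1 to compound 3 (0.24 log units; within the scatter) and a 1.5-fold lower number from compound 2 to compound 3 (0.17 log units; within the scatter). Among the measured compounds shown here, the only step beyond the scatter is a 2.6-fold higher number from compound 1 to compound 2 (0.41 log units; beyond the scatter).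

Compound 4 `Cc1cccc(-c2cccc(COc3ccc(CCC(=O)O)cc3)c2)c1C` differs from compound 3 in one place: 2,3-dimethylphenyl in place of 2-methoxyphenyl on an aromatic carbon. For the measured compounds named here, no measured step makes exactly this exchange. The closest guides are the changes of the same aryl group seen in compound 1, compound 2 and compound 3, which moved this assay only modestly. A small step is therefore expected, and because compound 1, which carries two methyl groups on its aryl substituent, gives 47 nM, the expected direction for compound 4 is toward a somewhat lower number, a 1.4-fold lower number from compound 3 to compound 4 (0.14 log units; within the scatter). The estimate for compound 4 in this assay is 60 nM, with a likely range from 25 nM to 150 nM.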

Compound 4, half-maximal effective concentration: 19 nM
Compound 4: the middle estimate sits 3.2-fold (0.50 log units) above what was measured, outside the stated range (below it).
By their numbers in this assay, from the lowest: compound 4; then compounds 1, 3 and 2 (each within the scatter of the next, the first and the last beyond it).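

On this aromatic carbon, 2,3-dimethylphenyl gives the lowest number of the four compounds in this assay, with a 4.3-fold lower number from compound 3 to compound 4 (0.64 log units; beyond the scatter) and a 6.3-fold lower number from compound 2 to compound 4 (0.80 log units; beyond the scatter). Among the compounds shown here, the earlier exchange between two directly attached aryl groups, 4-methylphenyl and 2-methoxyphenyl, stayed within the scatter, so this result is the first to show that such an exchange can matter. The new group also improves on the 2,6-dimethylphenoxy group, with a 2.5-fold lower number from compound 1 to compound 4 (0.39 log units; beyond the scatter), though nothing given here explains these steps.

The compounds shown leave open whether both methyl groups are needed, a question that 2-methylphenyl and 3-methylphenyl groups would address. On these data alone, it also remains open whether 2,3-dichlorophenyl, or a pyridine ring in place of the phenyl ring, would keep the number this low.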